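Changing the Group on a Sulfonyl Sulfur

A few compounds are considered here, and "the series" means these few. Any claim that something is new, unique, unknown or untested is made for them only; others in the source may bear on it.

Within the data shown here, in a functional assay on A2780 cells (Homo sapiens) for antiproliferative activity, read by sulforhodamine B assay, with a stated time of 72 h (a higher number here means a weaker inhibitor, a lower number a stronger inhibitor), compound 3 (`C[C@@H]1CN(S(=O)(=O)c2ccc(NC(=O)NCc3cccnc3)cc2)C[C@H](C)O1`) gives 15 nM as the only true number in this small set. Compound 1 (`O=C(NCc1ccc(Cl)nc1)Nc1ccc(S(=O)(=O)c2ccccc2)cc1`) gives > 2000 nM as a limit of the assay, not a number. Compound 2 (`O=C(NCc1cnccn1)Nc1ccc(S(=O)(=O)c2ccccc2)cc1`) gives > 2000 nM as a limit too.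

Compound 4 (`O=C(NCc1cccnc1)Nc1ccc(S(=O)(=O)N2CC3(COC3)C2)cc1`) differs from compound 3 in one place: a group of 7 heavy atoms (5 carbon, 1 nitrogen, 1 oxygen; 2 four-membered non-aromatic rings with 1 hetero atom each) in place of a group of 8 heavy atoms (6 carbon, 1 nitrogen, 1 oxygen; one six-membered non-aromatic ring with 2 hetero atoms), on a sulfonyl sulfur. Both groups carry no net charge, and only the leaving group has defined stereocentres.

Among the measured compounds shown here, the one measured step, a step that the two limits leave unreadable from compound 1 to compound 2, has no readable size. It lies at the limit of > 2000 nM in this assay, at which 2 of the 3 values shown sit, and concerns a different part of the molecule, so it offers nothing to carry over. The expectation therefore rests on compound 3 at 15 nM and on the similar counts of the two groups. Going by these compounds, the expected step, a 1.5-fold higher number from compound 3 to compound 4 (0.17 log units; within the scatter), is no larger than the usual scatter, and its direction stays open. For compound 4 the estimated value is 22 nM, with an expected range (6 nM to 90 nM).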

Compound 4, half-maximal inhibitory concentration: > 2000 nM
Compound 4 ended at the assay's limit; the forecaster's own chance of this, stated with the estimate: 3%; middle value at least 90-fold (1.95 log units) away from the limit.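

The result shows that the group on this sulfonyl sulfur matters greatly: in this assay, replacing 2,6-dimethylmorpholin-4-yl with the group of two four-membered rings gives an at least 130-fold higher number from compound 3 to compound 4 (2.12 log units; beyond the scatter). The two groups have no net charge and the same counts of hydrogen-bond donors and acceptors, so these simple counts do not separate an active compound from an inactive one here. Going by these compounds, the value of compound 4 is a limit and not a number, so the full size of the loss stays unknown, and compound 4 joins the compounds at that ceiling: the limit of > 2000 nM in this assay, at which 3 of the 4 values shown sit.

The compounds shown leave open whether the loss follows from ring size, from the two methyl groups or from the defined stereocentres. An unsubstituted morpholine or a piperidine on the same sulfur would help to tell these apart.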